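The source may report more compounds than this note shows. Statements on the series, on what has been measured and on what is new or still open speak of the compounds shown alone.

In an assay on NIH3T3 cells for inhibition of Sonic hedgehog protein (Mus musculus), read by a luciferase reporter, with a stated time of 48 h (on this read-out higher numbers stand for weaker inhibition and lower numbers for stronger inhibition), three close analogues have been measured. Compound 1 `Cc1cnc(Nc2ccc(C(=O)Nc3c(C)cccc3C)cc2)nc1-c1ccc(F)cc1` gives 2.2 nM, compound 2 `Cc1cnc(Nc2ccc(C(=O)Nc3c(C)cccc3C)cc2)nc1-c1ccncc1` gives 0.54 nM, and compound 3 `Cc1cnc(Nc2ccc(C(=O)Nc3c(C)cccc3C)cc2)nc1-c1cnn(C)c1` gives 10.6 nM, the highest number of the three. The step from compound 1 to compound 3 was a 4.8-fold higher number from compound 1 to compound 3 (0.68 log units; beyond the scatter), and the step from compound 2 to compound 3 was a 20-fold higher number from compound 2 to compound 3 (1.29 log units; beyond the scatter), so every exchange of the ring on this position has moved the read-out beyond the scatter. Compound 4 `Cc1cnc(Nc2ccc(C(=O)Nc3c(C)cccc3C)cc2)nc1-c1ccoc1` is the next step from compound 3: furan-3-yl in place of 1-methyl-1H-pyrazol-4-yl on an aromatic carbon. Among the measured compounds shown here, no measured pair shows this exact exchange; the two steps into compound 3 only show that a five-membered ring with two hetero atoms carried the highest number, while the six-membered rings of compound 1 and compound 2 stood beyond the scatter on the stronger side. Since furan-3-yl is again a five-membered ring, compound 4 is expected to land between compound 3 and compound 1, with a modest step of a 2.1-fold lower number from compound 3 to compound 4 (0.33 log units; beyond the scatter). Compound 4 is therefore estimated at 5 nM, with a range from 1.5 nM to 18 nM.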

Compound 4, half-maximal inhibitory concentration: 15.7 nM
Estimate against measurement, compound 4: 3.1-fold (0.50 log units) below, within the range that was stated.
By their numbers in this assay, from the lowest: compound 2; then compound 1; then compounds 3 and 4 (each within the scatter of the next).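

In this assay, replacing 1-methyl-1H-pyrazol-4-yl with furan-3-yl gave a 1.5-fold higher number from compound 3 to compound 4 (0.17 log units; within the scatter), so at this position the change from two ring hetero atoms to one, together with the loss of a heavy atom, did not separate the two five-membered rings. Both rings stayed on the weaker side of the two six-membered rings, as furan-3-yl shows with a 29-fold higher number from compound 2 to compound 4 (1.46 log units; beyond the scatter) and a 7.1-fold higher number from compound 1 to compound 4 (0.85 log units; beyond the scatter), and none of the four compounds goes against this grouping. Nothing given here accounts for the gap between the two ring sizes.

The compounds shown leave open whether the gap follows ring size or only the particular rings tested. A thiophen-3-yl ring, a pyridin-3-yl ring or a saturated morpholine ring at this position could help settle that.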